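A few compounds are considered here, and "the series" means these few. Any claim that something is new, unique, unknown or untested is made for them only; others in the source may bear on it.

Measured in a functional assay with Homo sapiens as the target, in the presence of a further agent that is not named here; a higher number here means a weaker inhibitor, a lower number a stronger inhibitor:
Compound 1 `CC(C)[C@H](NC(=O)[C@H](CC(=O)O)NC(=O)CCCOc1ccc(C(=N)N)cc1)C(N)=O`: 670 nM
Compound 2 `CC(C)[C@H](NC(=O)[C@H](CC(=O)O)NC(=O)CCCOc1ccc(C(=N)N)cc1)C(=O)O`: 100 nM
Compound 3 `CC(C)[C@H](NC(=O)[C@H](CC(=O)O)NC(=O)CCCOc1ccc(C(=N)N)cc1)C(=O)N1CCN(C)CC1`: 180 nM

Compound 3 holds the second highest of the three numbers, though its gap to compound 2 is not a real separation: a 1.8-fold higher number from compound 2 to compound 3 (0.26 log units; within the scatter) stays within the scatter, while a 3.7-fold lower number from compound 1 to compound 3 (0.57 log units; beyond the scatter) lies beyond it. Compound 4 `CCN(CC)C(=O)[C@@H](NC(=O)[C@H](CC(=O)O)NC(=O)CCCOc1ccc(C(=N)N)cc1)C(C)C` carries diethylamino in place of 4-methylpiperazin-1-yl on a carbonyl carbon. All three measured steps change that same carbonyl carbon. The largest is modest, a 6.7-fold lower number from compound 1 to compound 2 (0.83 log units; beyond the scatter), and the other step from the amino group is also modest, while the step between the hydroxy and 4-methylpiperazin-1-yl groups shows no separation. None of them tests diethylamino directly, so the expectation remains anchored on compound 3 at 180 nM. No step beyond the scatter is expected in this assay, and the expected change is a 1.1-fold higher number from compound 3 to compound 4 (0.05 log units; within the scatter). For compound 4 the estimated value is 200 nM, with an expected range of 80 nM to 500 nM.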

Compound 4, half-maximal inhibitory concentration: 250 nM
Estimate against measurement, compound 4: 1.3-fold (0.10 log units) below, and the stated range covers the measured number.
By their numbers in this assay, from the lowest: compounds 2, 3 and 4 (each within the scatter of the next, the first and the last beyond it); then compound 1.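

In this assay, exchanging the ring of 4-methylpiperazin-1-yl for the open-chain diethylamino on this carbonyl carbon gives no separation (a 1.4-fold higher number from compound 3 to compound 4 (0.14 log units; within the scatter)), so among these two groups the ring is not required to hold the number. Diethylamino does stand apart from amino (a 2.7-fold lower number from compound 1 to compound 4 (0.43 log units; beyond the scatter)) and, unlike 4-methylpiperazin-1-yl, also from hydroxy (a 2.5-fold higher number from compound 2 to compound 4 (0.40 log units; beyond the scatter)), which places compound 4 between compound 1 and compound 2. No measurement here bears on what lies behind these steps.

Still open, as far as these compounds go, is where a smaller dimethylamino or a ring such as morpholin-4-yl or piperidin-1-yl would fall on this carbonyl carbon in this assay. Also open, from the compounds shown here alone, is whether the same ranking of groups holds when the shared core carries a longer chain.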